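Working notes: from compound 1 to compound 4

The compounds below may be only part of what the source reports. "The series", "measured", "known", "first", "only" and "open" are said of these compounds alone.

Measured so far in an ADME assay on Vero cells (Chlorocebus sabaeus) for cytotoxicity; a lower number here means that less compound is tolerated, a higher number that more compound is tolerated:
compound 1 `N=C(NO)N/N=C/c1ccccc1Cl`: > 100000 nM
compound 2 `CN(C)c1ccc(/C=N/NC(=N)NO)cc1`: > 100000 nM
compound 3 `COc1ccc(/C=N/NC(=N)NO)cc1`: > 100000 nM

The value of compound 1 is a limit of the assay, not a number. The value of compound 2 is likewise a limit. The value of compound 3 is also a limit. Compound 1 thus stands at the limit of > 100000 nM in this assay, at which 3 of the 3 values shown sit, with no number of its own and nothing that ranks it against the other two. Among the measured compounds shown here, the only step between measured compounds, a step that the two limits leave unreadable from compound 2 to compound 3, cannot be read from two limits. The change to compound 4 `Cc1ccccc1/C=N/NC(=N)NO` is methyl in place of chloro on an aromatic carbon. For the measured compounds named here, no measured step bears on a methyl in place of a chloro, and the one step available is unreadable, so no step beyond the scatter is expected in this assay. Compound 4 is expected to give 150000 nM, in the range 60000 nM to 400000 nM, most probably reported again as a limit. The expected step that the limit leaves unreadable from compound 1 to compound 4 is none beyond the scatter.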

Compound 4, half-maximal cytotoxic concentration: > 100000 nM
Compound 4: no number, only a limit; the forecaster's own chance of this, stated with the estimate: 85%; the middle value lies beyond the limit too.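

In this assay compound 4 gives > 100000 nM as a limit and not a number. No step can be read between compound 1 and compound 4: the limit of > 100000 nM in this assay, at which 4 of the 4 values shown sit. At what concentration any of the compounds shown becomes cytotoxic, and how they rank, stays open.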